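The source may report more compounds than this note shows. Statements on the series, on what has been measured and on what is new or still open speak of the compounds shown alone.

Compound 1 `CC(C)(C)c1ccc(Cn2nc(-c3ccc(Cl)cc3)cc2C(=O)N/N=C/c2cccc(O)c2O)cc1`: 400 nM
Compound 2 `O=C(N/N=C/c1ccccc1O)c1cc(-c2ccc(Cl)cc2)nn1Cc1ccc(Cl)nc1`: 300 nM
Compound 3 `O=C(N/N=C/c1ccc(F)cc1F)c1cc(-c2ccc(Cl)cc2)nn1Cc1ccc(Cl)nc1`: 9050 nM

In a functional assay on A549 cells (Homo sapiens) for antiproliferative activity, read by BrdU incorporation, with a stated time of 48 h (on this read-out higher numbers stand for weaker inhibition and lower numbers for stronger inhibition), compound 3 gives 9050 nM, the highest of the three numbers, with compound 1 and compound 2 both far lower. The step of a 30-fold higher number from compound 2 to compound 3 (1.48 log units; beyond the scatter) shows how much the 2,4-difluorophenyl costs in place of 2-hydroxyphenyl on the carbon with a double bond to nitrogen. Compound 4 `CC(C)(C)c1ccc(Cn2nc(-c3ccc(Cl)cc3)cc2C(=O)N/N=C/c2ccc(F)cc2F)cc1` keeps that 2,4-difluorophenyl and alters only the other end: 4-(tert-butyl)phenyl in place of 6-chloropyridin-3-yl on a saturated chain carbon bound to an aromatic nitrogen. Among the compounds with values here, no measured step isolates this swap; compound 1 and compound 2 differ here but also on the carbon with a double bond to nitrogen, and their values lie close together. The swap is therefore expected to move this assay little, and the expected step of a 1.1-fold lower number from compound 3 to compound 4 (0.05 log units; within the scatter) stays within the scatter. Compound 4 is estimated at 8000 nM, between 3000 nM and 25000 nM.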

Compound 4, half-maximal inhibitory concentration: > 100000 nM
Compound 4 ended at the assay's limit; the forecaster's own chance of this, stated with the estimate: 10%; at least 12-fold (1.09 log units) between middle value and limit.
By their numbers in this assay, from the lowest: compounds 2 and 1 (each within the scatter of the next); then compound 3. At a limit, above all of these: compound 4.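

The reading for compound 4 in this assay is a limit of the assay, not a number: the limit of > 100000 nM in this assay, at which 1 of the 4 values shown sits. The step of an at least 11-fold higher number from compound 3 to compound 4 (1.04 log units; beyond the scatter) shows that, with 2,4-difluorophenyl kept, the swap to 4-(tert-butyl)phenyl on a saturated chain carbon bound to an aromatic nitrogen is far from neutral. The step of an at least 250-fold higher number from compound 1 to compound 4 (2.39 log units; beyond the scatter) shows that, with 4-(tert-butyl)benzyl kept, 2,4-difluorophenyl in place of 2,3-dihydroxyphenyl also costs heavily.

The same swap with a hydroxylated phenyl kept cannot be read from these compounds. Also open, as far as these compounds go, is how an amine or a carboxylic acid on that phenyl would behave.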